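This account rests on a few compounds, and the source may have more. Where it says the series, first, only, none or still open, it means among the compounds named here.

Compound 1 `CC1(C)Cc2c(ccc(C(=O)/C=C/c3ccc(Cl)cc3Cl)c2OCc2ccccc2)O1` gives in a functional assay on B16 cells (Mus musculus) for antiproliferative activity, read by MTT assay, with a stated time of 48 h (a lower number here means a stronger inhibitor, a higher number a weaker inhibitor), only the limit > 100000 nM.
Compound 2 `CC1(C)Cc2c(ccc(C(=O)/C=C/c3cn(-c4ccccc4)nc3-c3cccc([N+](=O)[O-])c3)c2OCc2ccccc2)O1` gives in this assay only the limit > 50000 nM.

Among the measured compounds shown here, compound 1 thus stands at the limit of > 100000 nM in this assay, at which 1 of the 2 values shown sits, and neither measured compound yields a number rather than a limit, so no measured step exists to lean on. Compound 3 `CC1(C)Cc2c(ccc(C(=O)/C=C/c3ccc(F)cc3)c2OCc2ccccc2)O1` differs from compound 1 in one place: 4-fluorophenyl in place of 2,4-dichlorophenyl on a double-bonded chain carbon bound to a double-bonded chain carbon. With both measured values sitting at limits, this change is expected to move the result little, and the expected step of a number no higher from compound 1 to compound 3 (the limit leaves the size open) is none beyond the scatter. Compound 3 is expected at 100000 nM, with a range from 30000 nM to 300000 nM, most likely reported once more only as a limit.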

Compound 3, half-maximal inhibitory concentration: > 100000 nM
Compound 3: only a limit was reported; the forecaster's own chance of this, stated with the estimate: 80%; the middle value sits exactly at the limit.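

Compound 1 and compound 3 both end at the same limit, so no step between them can be read: the limit of > 100000 nM in this assay, at which 2 of the 3 values shown sit.

The compounds shown leave open how strongly any of them acts in this assay, and whether 4-fluorophenyl in place of 2,4-dichlorophenyl changes that at all.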